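From 1H-pyrrol-1-yl to 4-methylpiperazin-1-yl in Compound 2

The source may report more compounds than this note shows. Statements on the series, on what has been measured and on what is new or still open speak of the compounds shown alone.

In a functional assay on K562 cells (Homo sapiens) for antiproliferative activity, read by MTT assay, with a stated time of 48 h (a lower number here means a stronger inhibitor, a higher number a weaker inhibitor), compound 1 `Cn1cc(C2=C(c3nn(CCn4ccnc4)c4ncccc34)C(=O)N(c3ccccc3)C2=O)c2ccccc21` gives 26400 nM and compound 2 `Cn1cc(C2=C(c3nn(CCCn4cccc4)c4ncccc34)C(=O)NC2=O)c2ccccc21` gives 21600 nM, the two lying within the scatter of each other. Compound 3 `Cn1cc(C2=C(c3nn(CCCN4CCCCC4)c4ncccc34)C(=O)N(c3cccc4ccccc34)C2=O)c2ccccc21`, at 3180 nM, gives a lower number than compound 2, beyond the scatter. Compound 4 `CN1CCN(CCCn2nc(C3=C(c4cn(C)c5ccccc45)C(=O)NC3=O)c3cccnc32)CC1` is not yet measured and differs from compound 2 in one place: 4-methylpiperazin-1-yl in place of 1H-pyrrol-1-yl on a saturated chain carbon, three bonds along the chain from an aromatic nitrogen. Going by the values given here, no measured pair isolates this change. Compound 3 also carries a non-aromatic ring on its propyl chain, though it differs elsewhere too, and its 3180 nM points to a moderate drop. In this assay the expected change, beyond the scatter, is a 2.7-fold lower number from compound 2 to compound 4 (0.43 log units; beyond the scatter). For compound 4 the estimate is 8000 nM, with an expected range of 2500 nM to 25000 nM.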

Compound 4, half-maximal inhibitory concentration: 46700 nM
Compound 4: middle estimate off by 5.8-fold (0.77 log units), on the low side; the measured number lies above the stated range.
By their numbers in this assay, from the lowest: compound 3; then compounds 2, 1 and 4 (each within the scatter of the next, the first and the last beyond it).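

Going by these compounds alone, this is the only direct reading of the change at this position: 4-methylpiperazin-1-yl in place of 1H-pyrrol-1-yl gives a 2.2-fold higher number from compound 2 to compound 4 (0.33 log units; beyond the scatter), a modest loss rather than a gain. Compound 3 differs from compound 4 in more than one place, so its lower number cannot be read as a general effect of a non-aromatic ring on this propyl chain. No measurement here accounts for the step. As far as these compounds go, whether morpholin-4-yl or a dimethylamino group on the same chain would follow 4-methylpiperazin-1-yl remains open. So does whether the step holds on a shorter chain.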